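The source may report more compounds than this note shows. Statements on the series, on what has been measured and on what is new or still open speak of the compounds shown alone.

In a functional assay on the whole organism for positive allosteric modulation, with Mus musculus as the target (on this read-out higher numbers stand for an effect only at larger amounts of compound and lower numbers for an effect already at smaller amounts), compound 1 `CCC(=O)N(c1ccc(Cl)cc1)C1CCCC1N(C)C` reads > 50 mg/kg as a limit and not a number. Compound 2 `CCC(=O)N(c1ccc(OC)cc1)C1CCCC1N(C)C` reads > 50 mg/kg; > 50 mg/kg (2 entries) and is a limit too. Compound 3 `CCC(=O)N(c1ccc(F)cc1)C1CCCC1N(C)C` reads > 50 mg/kg and likewise stands only as a limit. Compound 4 `CCC(=O)N(c1ccc(C(F)(F)F)cc1)C1CCCC1N(C)C` differs from compound 3 by trifluoromethyl in place of fluoro on an aromatic carbon with trifluoromethyl in place of fluoro on an aromatic carbon. Among the compounds with values here, the only measured step of a similar kind is a step that the two limits leave unreadable from compound 1 to compound 3 and its size cannot be read. Within the data shown here, the series so far offers the limit of > 50 mg/kg in this assay, at which 2 of the 3 values shown sit, and no readable step, so no direction can be argued. No step beyond the scatter is therefore expected, and a number no higher from compound 3 to compound 4 (the limit leaves the size open) is the estimated step in this assay for now. Compound 4 is estimated at 50 mg/kg with an expected range from 20 mg/kg to 100 mg/kg on this read-out.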

Compound 4, dose for half-maximal effect: 10 mg/kg
Estimate against measurement, compound 4: 5.0-fold (0.70 log units) above; measured number outside the range, below it.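

In this assay, the position para to a large group now gives readable steps: trifluoromethyl in place of fluoro gives an at least 5.0-fold lower number from compound 3 to compound 4 (0.69 log units; beyond the scatter), and trifluoromethyl in place of chloro gives an at least 5.0-fold lower number from compound 1 to compound 4 (0.69 log units; beyond the scatter). The series therefore responds to a change at this position. The step between the chloro and fluoro compounds still cannot be read, and the assay limit leaves any order among the earlier compounds hidden: the limit of > 50 mg/kg in this assay, at which 2 of the 4 values shown sit.

As far as these compounds go, the full size of both steps remains open, as each starts from a limit. From the compounds shown here alone, whether the lower number is specific to trifluoromethyl also remains open; a nitrile or a tert-butyl group at this position would test that.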